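From Fluoro to Methyl on the Terminal Aryl Ring

The source may hold more compounds than are shown below. What is called first, only, known or untested is meant among the compounds shown, and "the series" means these compounds.

Of the compounds shown here, three sharing one core have been measured for tolerance of cell exposure. Compound 1 `CSc1ccc(/C=N/NC(=O)COc2cccc3ccccc23)cc1` was tested in an ADME assay on HEL cells (Homo sapiens) for cytotoxicity; a higher number here means that more compound is tolerated, a lower number that less compound is tolerated; compound 1 gives >= 100 ug/mL, which is a limit of the assay and not a number. Compound 2 `O=C(COc1cccc2ccccc12)N/N=C/c1ccccc1` gives 100 ug/mL in this assay. Compound 3 `O=C(COc1cccc2ccccc12)N/N=C/c1ccc(F)cc1` gives 100 ug/mL in this assay and stands level with compound 2 at the digits shown; the step of no change at the digits printed from compound 2 to compound 3 (within the scatter) lies within the scatter. The steps of a number no higher from compound 1 to compound 2 (the limit leaves the size open) and a number no higher from compound 1 to compound 3 (the limit leaves the size open) cannot be sized, since compound 1 sits at the limit of >= 100 ug/mL in this assay, at which 1 of the 3 values shown sits.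

Compound 4 `Cc1ccc(/C=N/NC(=O)COc2cccc3ccccc23)cc1` is not yet measured. The change is methyl in place of fluoro on an aromatic carbon. Of the measured steps, no change at the digits printed from compound 2 to compound 3 (within the scatter) bears most directly. It also exchanged a single small group on an aromatic carbon of that ring and gave no change within the scatter. The steps from compound 1, which carries methylsulfanyl on that carbon, leave their size open and so add nothing readable. No step beyond the scatter is therefore expected in this assay. Compound 4 is expected to give 100 ug/mL, between 50 ug/mL and 200 ug/mL. The expected step is no change at the digits printed from compound 3 to compound 4 (within the scatter).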

Compound 4, minimum cytotoxic concentration: 20 ug/mL
The estimate for compound 4 lay 5.0-fold (0.70 log units) above the measured number; measured number below the stated range.
By their numbers in this assay, from the lowest: compound 4; then compounds 2 and 3 (each within the scatter of the next).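

The methyl compound shows that this position, on an aromatic carbon para to a large group, is not indifferent to a small exchange in this assay: there is a 5.0-fold lower number from compound 3 to compound 4 (0.70 log units; beyond the scatter), and likewise a 5.0-fold lower number from compound 2 to compound 4 (0.70 log units; beyond the scatter), although hydrogen and fluoro had stood level at this carbon. Fluoro and methyl each count one heavy atom, with no ring, no hydrogen-bond donor or acceptor and no net charge, so those counts do not separate the two groups, and the replacement of methylsulfanyl by methyl also gives an at least 5.0-fold lower number from compound 1 to compound 4 (0.69 log units; beyond the scatter). Compound 1 carries a limit and not a number, so that last step has an open size: the limit of >= 100 ug/mL in this assay, at which 1 of the 4 values shown sits.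

As far as these compounds go, whether the lower number is confined to methyl, or also appears with ethyl, methoxy, an amine or a carboxylic acid on the same carbon, stays open. The compounds shown also give no cause for the separation of methyl from hydrogen and fluoro, and they cannot say whether the same exchange would act alike on another core.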